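Aryl swap on the ring nitrogen: compound 2 to compound 4

A few compounds are considered here, and "the series" means these few. Any claim that something is new, unique, unknown or untested is made for them only; others in the source may bear on it.

Measured so far:
compound 1 `Cc1nc(-c2ccccc2F)c(C(=O)N2CCN(c3cccc(Cl)c3)CC2)o1`: 39.4 nM
compound 2 `Cc1nc(-c2ccccc2F)c(C(=O)N2CCN(c3cc(Cl)cc(Cl)c3)CC2)o1`: 60.2 nM
compound 3 `Cc1nc(-c2cccc(F)c2)c(C(=O)N2CCN(c3cc(Cl)cc(Cl)c3)CC2)o1`: 41.7 nM

In a functional assay on HL-60 cells (Homo sapiens) for inhibition, read by MTT assay, with a stated time of 72 h (a higher number here means a weaker inhibitor, a lower number a stronger inhibitor), compound 2 gives the largest of the three numbers, yet neither step from it leaves the scatter: a 1.5-fold higher number from compound 1 to compound 2 (0.18 log units; within the scatter) and a 1.4-fold lower number from compound 2 to compound 3 (0.16 log units; within the scatter). Compound 4 `COc1ccc(Cl)cc1N1CCN(C(=O)c2oc(C)nc2-c2ccccc2F)CC1` is the next change at the same position: 5-chloro-2-methoxyphenyl in place of 3,5-dichlorophenyl on an amine nitrogen in a ring. Within the data shown here, the only measured step at this ring is the one from compound 1 to compound 2, and it stayed within the scatter; no measured step exchanges a chloro for a methoxy or moves substituents around this ring. The expectation for this assay is therefore no step beyond the scatter, estimated as a 1.2-fold lower number from compound 2 to compound 4 (0.08 log units; within the scatter). Compound 4 is expected to give 50 nM, within 18 nM to 140 nM.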

Compound 4, half-maximal inhibitory concentration: 153 nM
The estimate for compound 4 lay 3.1-fold (0.49 log units) below the measured number; measured number outside the range, above it.
By their numbers in this assay, from the lowest: compounds 1, 3 and 2 (each within the scatter of the next); then compound 4.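

In this assay, among these compounds, the aryl group on the ring nitrogen is no longer silent: 5-chloro-2-methoxyphenyl in place of 3,5-dichlorophenyl gives a 2.5-fold higher number from compound 2 to compound 4 (0.41 log units; beyond the scatter) as the first step at this ring beyond the scatter. The other new step is a 3.9-fold higher number from compound 1 to compound 4 (0.59 log units; beyond the scatter), in the same direction, so both steps raise the number. The data offer no measured explanation for either step.

Open, from the compounds shown here alone, is whether a hydroxy or ethoxy group in place of the methoxy would give a step of similar size.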